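This account rests on a few compounds, and the source may have more. Where it says the series, first, only, none or still open, it means among the compounds named here.

Compound 3 `O=C(O)c1ccccc1-c1ccc(CCc2ncc(Cc3ccc(F)cc3)[nH]2)cc1` stands second highest of the three measured compounds in an in vitro functional assay on cells for agonist activity at Bombesin receptor subtype-3 (Mus musculus), read by luminescence and calcium flux; on this read-out higher numbers stand for an effect only at larger amounts of compound and lower numbers for an effect already at smaller amounts: compound 3 gives 50 nM, compound 2 `O=C(O)c1ccccc1-c1ccc(CCc2ncc(Cc3ccc(Cl)cc3)[nH]2)cc1` gives 102 nM, and compound 1 `O=C(O)c1ccccc1-c1ccc(CCc2ncc(CC3CCCC3)[nH]2)cc1` gives 7.9 nM. The step of a 2.0-fold lower number from compound 2 to compound 3 (0.31 log units; beyond the scatter) was modest, a 6.3-fold higher number from compound 1 to compound 3 (0.80 log units; beyond the scatter) was modest, and a 13-fold higher number from compound 1 to compound 2 (1.11 log units; beyond the scatter) was large. Compound 4 `O=C(O)c1ccccc1-c1ccc(CCc2ncc(-c3ccccc3)[nH]2)cc1` differs from compound 3 by phenyl in place of 4-fluorobenzyl on an aromatic carbon. Within the data shown here, none of the measured steps removes the saturated chain carbon, so they bear only loosely on this change; the nearest, a 2.0-fold lower number from compound 2 to compound 3 (0.31 log units; beyond the scatter), shows that altering the aromatic ring alone shifts the number in this assay modestly. Compound 4 is therefore expected to show a 2.4-fold higher number from compound 3 to compound 4 (0.38 log units; beyond the scatter), with the direction uncertain. Compound 4 is estimated at 120 nM, with a range from 25 nM to 600 nM.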

Compound 4, half-maximal effective concentration: 872 nM
Estimate against measurement, compound 4: 7.3-fold (0.86 log units) below, outside the stated range (above it).
By their numbers in this assay, from the lowest: compound 1; then compound 3; then compound 2; then compound 4.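

In this assay, phenyl in place of 4-fluorobenzyl on this aromatic carbon gives a 17-fold higher number from compound 3 to compound 4 (1.24 log units; beyond the scatter) and phenyl in place of 4-chlorobenzyl gives an 8.5-fold higher number from compound 2 to compound 4 (0.93 log units; beyond the scatter) so this change moves the number further than fluoro in place of chloro did. Against cyclopentylmethyl the change gives a 110-fold higher number from compound 1 to compound 4 (2.04 log units; beyond the scatter) and compound 4 holds the highest number of the four.

From the compounds shown here alone, the change removes the saturated chain carbon and the ring substituent together, so their shares stay unseparated, and whether a longer chain or an amine at that carbon would keep the lower numbers remains open. Nothing available here accounts for the rise in the number.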